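The source may hold more compounds than are shown below. What is called first, only, known or untested is meant among the compounds shown, and "the series" means these compounds.

Compound 1 `COc1ccc(C(=O)OCC2Oc3ccc([C@H]4Oc5cc(O)cc(O)c5C(=O)[C@@H]4O)cc3OC2c2ccc(O)c(OC)c2)cc1`: in a functional assay, read by spectrophotometry, with a stated time of 30 min (a lower number here means that less compound is needed, a higher number that more compound is needed for the effect), compound 1 gives 73300 nM.
Compound 2 `COc1cc(C2Oc3cc([C@H]4Oc5cc(O)cc(O)c5C(=O)[C@@H]4O)ccc3OC2COC(=O)c2ccc(N)cc2)ccc1O`: in this assay compound 2 gives 128000 nM.
Compound 3 `COc1cc(C2Oc3cc([C@H]4Oc5cc(O)cc(O)c5C(=O)[C@@H]4O)ccc3OC2COC(=O)c2cc(N)cc([N+](=O)[O-])c2)ccc1O`: in this assay compound 3 reaches only the limit of the assay, > 300000 nM.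

Compound 3 thus stands at the top of the three values, where (the limit of > 300000 nM in this assay, at which 1 of the 3 values shown sits), and it has no number of its own. The steps into it were an at least 4.0-fold higher number from compound 1 to compound 3 (0.61 log units; beyond the scatter) and an at least 2.3-fold higher number from compound 2 to compound 3 (0.36 log units; beyond the scatter), both beyond the scatter, so the 3-amino-5-nitrophenyl group went along with a higher number than either the 4-methoxyphenyl or the 4-aminophenyl ester.

Compound 4 `COc1cc(C2Oc3cc([C@H]4Oc5cc(O)cc(O)c5C(=O)[C@@H]4O)ccc3OC2COC(=O)/C=C/c2ccc(C)cc2)ccc1O` takes the change (2-(4-methylphenyl)ethenyl in place of 3-amino-5-nitrophenyl on a carbonyl carbon). Among the compounds with values here, no measured pair carries this exact change; what bears on it is that removing the 3-amino-5-nitrophenyl group reverses the two steps that raised the number, and that compound 1 with its 4-methoxyphenyl ester gave 73300 nM. Compound 4 is therefore expected to give a lower number than compound 3, a step of about an at least 3.3-fold lower number from compound 3 to compound 4 (0.52 log units; beyond the scatter). Compound 4 is estimated at 90000 nM, most likely between 35000 nM and 250000 nM.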

Compound 4, half-maximal effective concentration: 136000 nM
The estimate for compound 4 lay 1.5-fold (0.18 log units) below the measured number; low and high end bracket the measured number.
By their numbers in this assay, from the lowest: compounds 1, 2 and 4 (each within the scatter of the next). At a limit, above all of these: compound 3.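

In this assay compound 3 carries only a limit of the assay, not a number: the limit of > 300000 nM in this assay, at which 1 of the 4 values shown sits. Replacing its 3-amino-5-nitrophenyl group on the carbonyl carbon with 2-(4-methylphenyl)ethenyl gives an at least 2.2-fold lower number from compound 3 to compound 4 (0.34 log units; beyond the scatter), so this position also accepts a group with an ethenyl link and with no hydrogen-bond donors or acceptors. The same group gives a 1.1-fold higher number from compound 2 to compound 4 (0.03 log units; within the scatter) and a 1.9-fold higher number from compound 1 to compound 4 (0.27 log units; within the scatter), both within the scatter, so the 4-aminophenyl, 4-methoxyphenyl and 2-(4-methylphenyl)ethenyl groups are not told apart here, and only the 3-amino-5-nitrophenyl group stands apart.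

As far as these compounds go, it remains open whether the nitro group alone, without the amino group, goes with the limit. From the compounds shown here alone, it also remains open how an alkyl chain, or a phenyl ring carrying a carboxylic acid, would behave on this carbonyl carbon.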